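Difluoromethyl for Isopropyl on a Shared Core

The source may report more compounds than this note shows. Statements on the series, on what has been measured and on what is new or still open speak of the compounds shown alone.

Of the compounds shown here, three from this series have been measured in an ADME assay on microsomes from liver (Mus musculus) for metabolic stability; on this read-out lower numbers stand for slow clearance and higher numbers for fast clearance. Compound 1 `CCOc1cc([C@](O)(CCN(C)C)[C@@H](c2cc3cc(Br)ccc3nc2OC)c2cccc(OC)c2F)cc(OC)n1` gives 14 uL/min. Compound 2 `COc1cc([C@](O)(CCN(C)C)[C@@H](c2cc3cc(Br)ccc3nc2OC)c2ccnc(OC)c2OC)cc(OC(C)C)n1` gives 6.7 uL/min, and compound 3 `COc1cc([C@](O)(CCN(C)C)[C@@H](c2cc3cc(C#N)ccc3nc2OC)c2cccc(C)c2F)cc(OC(F)F)n1` gives 5.9 uL/min. Compound 2 stands second highest of the three: its number and that of compound 3 lie within the scatter of each other, while compound 1 lies beyond the scatter above it. Compound 4 `COc1cc([C@](O)(CCN(C)C)[C@@H](c2cc3cc(Br)ccc3nc2OC)c2ccnc(OC)c2OC)cc(OC(F)F)n1` is the next compound for this assay. It differs from compound 2 by difluoromethyl in place of isopropyl on an oxygen on an aromatic ring. Among the compounds with values here, no single-change step between measured compounds shows what this change does. In this assay a step of the size a 1.1-fold lower number from compound 2 to compound 4 (0.05 log units; within the scatter) is expected, not beyond the scatter in either direction. Compound 4 is therefore estimated at 6 uL/min, within a range from 3 uL/min to 13 uL/min.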

Compound 4, intrinsic clearance in a liver preparation (reported as CLH), per the amount of preparation that the assay uses: 4.9 uL/min
Compound 4: the middle estimate sits 1.2-fold (0.09 log units) above what was measured; the measured number falls inside the stated range.
By their numbers in this assay, from the lowest: compounds 4, 3 and 2 (each within the scatter of the next); then compound 1.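

In this assay, within the data shown here, the exchange gives the first single-change reading at this position: difluoromethyl in place of isopropyl on an oxygen on an aromatic ring yields a 1.4-fold lower number from compound 2 to compound 4 (0.14 log units; within the scatter). On this one pair, the two groups cannot be told apart. No supporting data bear on this result.

Going by these compounds, what a longer chain or an amine would do on this oxygen remains open. So does whether the same exchange gives a similar step when other parts of the shared core differ, as they do in compound 1 and compound 3.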